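A few compounds are considered here, and "the series" means these few. Any claim that something is new, unique, unknown or untested is made for them only; others in the source may bear on it.

In an ADME assay on microsomes from liver (Mus musculus) for metabolic stability, tested at 5 uM (a lower number here means that the compound disappears faster, a higher number that the compound lasts longer), compound 1 (`CCCCCCNc1ccc(C(=O)O)cc1S(N)(=O)=O`) reports > 1 h, which is a limit of the assay and not a number. Compound 2 (`CCCCCCCCNc1ccc(C(=O)O)cc1S(N)(=O)=O`) gives 0.3 h and compound 3 (`CCCCCCNc1ccc(C(=O)O)cc1S(=O)(=O)NC`) gives 0.483 h, two values that lie within the scatter of each other.

The next structure, compound 4 (`CCCCCCCCNc1ccc(C(=O)O)cc1S(=O)(=O)NC`), differs from compound 3 by ethyl in place of hydrogen on a saturated chain carbon, six bonds along the chain from a nitrogen on an aromatic ring. It keeps the methyl on the sulfonamide nitrogen and adds the ethyl on the saturated chain carbon. The ethyl change has one measured precedent, an at least 3.3-fold lower number from compound 1 to compound 2 (0.52 log units; beyond the scatter). The methyl change gave an at least 2.0-fold lower number from compound 1 to compound 3 (0.31 log units; beyond the scatter). Both sizes are minimums, and only the first is the same change as the one at hand.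

Resting on compound 2 and its step, a drop of similar size, beyond the scatter, is expected in this assay. The expected step is a 3.2-fold lower number from compound 3 to compound 4 (0.51 log units; beyond the scatter). For compound 4 the half-life is estimated at 0.15 h, with an expected range of 0.05 h to 0.4 h.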

Compound 4, half-life: 0.2 h
Beside the measured number, compound 4's estimate is 1.3-fold (0.12 log units) below it; measured number inside the range.
By their numbers in this assay, from the lowest: compounds 4, 2 and 3 (each within the scatter of the next, the first and the last beyond it). At a limit, above all of these: compound 1.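

The ethyl change now has a step with a number at both ends: in this assay it gives a 2.4-fold lower number from compound 3 to compound 4 (0.38 log units; beyond the scatter), so the fall seen for this change also appears on the core with a methyl on the sulfonamide nitrogen. How closely the two cases match in size remains unsettled: the same change on two cores in this assay, an at least 3.3-fold lower number (0.52 log units; beyond the scatter) from compound 1 to compound 2 and a 2.4-fold lower number (0.38 log units; beyond the scatter) from compound 3 to compound 4; the limit leaves it open whether they differ The methyl change, with the ethyl in place, gives a 1.5-fold lower number from compound 2 to compound 4 (0.18 log units; within the scatter), a step that stays within the scatter.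

The compounds shown leave open how a still longer chain, or an amine or a hydroxyl on the saturated chain, would read in this assay. They also leave open whether an ethyl or a cyclopropyl on the sulfonamide nitrogen would give a step beyond the scatter.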